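The compounds below may be only part of what the source reports. "The series", "measured", "known", "first", "only" and "open" are said of these compounds alone.

Measured compounds:
compound 1 `CC1=CC[C@H](C(C)(C)NC(=S)N/N=C/c2ccccc2O)CC1`: 2200 nM
compound 2 `CC1=CC[C@H](C(C)(C)NC(=S)N/N=C/c2ccco2)CC1`: 9300 nM

Both compounds share the same core and differ only in the aryl group on the carbon that carries the double bond to nitrogen. In a functional assay on MCF7 cells (Homo sapiens) for inhibition, read by sulforhodamine B assay, with a stated time of 48 h (a lower number here means a stronger inhibitor of growth, a higher number a weaker inhibitor of growth), compound 1 gives 2200 nM, while compound 2 gives 9300 nM. Among the measured compounds shown here, the single step recorded, a 4.2-fold higher number from compound 1 to compound 2 (0.63 log units; beyond the scatter), shows that replacing the 2-hydroxyphenyl group with furan-2-yl weakened growth inhibition. For the measured compounds named here, compound 2 therefore stands at the highest number of the two, with compound 1 as its only neighbour.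

Compound 3 `CC1=CC[C@H](C(C)(C)NC(=S)N/N=C/c2cccs2)CC1` is the next member of this pair. The change is thiophen-2-yl in place of furan-2-yl on a carbon with a double bond to nitrogen. Going by the values given here, only one measured step bears on this position, and it concerns a different exchange: a phenol ring giving way to a five-membered heteroaromatic ring. Among the compounds with values here, no step here compares two five-membered rings of the same size and acceptor count. The expectation is therefore modest: compound 3 is expected to give roughly 6000 nM, within a range from 2500 nM to 15000 nM, which means a step of a 1.6-fold lower number from compound 2 to compound 3 (0.19 log units; within the scatter) that may not exceed the scatter.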

Compound 3, concentration for 50% growth inhibition: 4800 nM
Compound 3: the middle estimate sits 1.3-fold (0.10 log units) above what was measured, and the stated range covers the measured number.
By their numbers in this assay, from the lowest: compound 1; then compounds 3 and 2 (each within the scatter of the next).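

In this assay, exchanging one five-membered aromatic ring for the other at this position gives a 1.9-fold lower number from compound 2 to compound 3 (0.29 log units; within the scatter) and so, with sulfur in place of oxygen in a ring of the same size, compound 3 cannot be told apart from compound 2 in this read-out. Set against the 2-hydroxyphenyl group, thiophen-2-yl gives a 2.2-fold higher number from compound 1 to compound 3 (0.34 log units; beyond the scatter) and this step, though modest, is beyond the scatter, so both five-membered rings now stand apart from compound 1, which has the lowest number of the three. Nothing measured here explains why the two five-membered rings sit together or why compound 1 stands apart from them.

The compounds shown leave open whether the hydroxyl of the 2-hydroxyphenyl group matters in itself, as neither a plain phenyl ring nor a 2-methoxyphenyl ring appears among them. Also open, on these data alone, is where a ring carrying nitrogen, such as pyridin-2-yl, or a five-membered ring bearing its own hydroxyl or methyl group, would fall at this place.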